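Moving the piperidine ring into the chain of compound 3

The source may report more compounds than this note shows. Statements on the series, on what has been measured and on what is new or still open speak of the compounds shown alone.

Measured compounds:
compound 1 `CCCC1CCN(CCCCC(=O)c2cc(Cl)c(N)cc2OCc2cc(OC)cc(OC)c2)CC1` 7.7
compound 2 `COc1cc(COc2cc(N)c(Cl)cc2C(=O)CCCCN2CCC(OC)CC2)cc(OC)c1` 8.4
compound 3 `COc1cc(COc2cc(N)c(Cl)cc2C(=O)CCCCN2CCC(NC(N)=O)CC2)cc(OC)c1` 8.5

In a functional assay for antagonist activity at 5-hydroxytryptamine receptor 4 (Rattus norvegicus) (a higher number here means a more potent compound, by a factor of ten per unit of this negative logarithm, a lower number a less potent compound), compound 3 gives the highest of the three numbers, yet compound 2 lies within the scatter of it, a number 0.10 log units higher from compound 2 to compound 3 (within the scatter), while compound 1 lies further off, a number 0.80 log units higher from compound 1 to compound 3 (beyond the scatter). Compound 4 `CCCCCN1CCC(CCC(=O)c2cc(Cl)c(N)cc2OCc2cc(OC)cc(OC)c2)CC1` differs from compound 3 in one place: 1-pentylpiperidin-4-yl in place of 2-(4-ureidopiperidin-1-yl)ethyl on a saturated chain carbon, two bonds along the chain from a carbonyl carbon. Within the data shown here, no measured step matches this change, in which the ring nitrogen loses its place in the chain and the ureido group disappears. Among the measured compounds shown here, the steps that bear on it are those from compound 1, which also carries only a carbon chain on the ring: a number 0.70 log units higher from compound 1 to compound 2 (beyond the scatter) and a number 0.80 log units higher from compound 1 to compound 3 (beyond the scatter), both gains on adding a methoxy or ureido group. Compound 4 carries neither, so in this assay a drop beyond the scatter is expected, a number 1.20 log units lower from compound 3 to compound 4 (beyond the scatter), towards the level of compound 1. For compound 4 the estimated value in this assay is 7.3, with a range from 6.5 to 8.1.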

Compound 4, negative logarithm of the antagonist equilibrium constant: 9.1
Estimate against measurement, compound 4: 1.80 log units below, and the stated range ends below it.
By their numbers in this assay, from the lowest: compound 1; then compounds 2 and 3 (each within the scatter of the next); then compound 4.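

In this assay the change at this position gives a gain in every comparison (a number 0.60 log units higher from compound 3 to compound 4 (beyond the scatter); a number 0.70 log units higher from compound 2 to compound 4 (beyond the scatter); a number 1.40 log units higher from compound 1 to compound 4 (beyond the scatter)). Compound 4 carries neither a ureido nor a methoxy group, yet it stands above all three earlier compounds, so neither group is required for a high number once the piperidine ring sits in the chain with a pentyl group on its nitrogen. No measured evidence here explains this gain.

The compounds shown do not separate the new place of the ring from the pentyl group, as both arrive in one change. They also leave open whether a longer chain on the ring nitrogen, or a pentyl chain ending in an amine, a carboxylic acid or a ureido group, would hold this level.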